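Adding a methoxy group to compound 1

A few compounds are considered here, and "the series" means these few. Any claim that something is new, unique, unknown or untested is made for them only; others in the source may bear on it.

Measured in a functional assay on MGC-803 cells (Homo sapiens) for antiproliferative activity, read by MTT assay, with a stated time of 48 h; a higher number here means a weaker inhibitor, a lower number a stronger inhibitor:
Compound 1 `COc1ccc(CN(C(=O)CSc2nc3ccccc3s2)c2cc(OC)c(OC)c(OC)c2)cc1O`: 35 nM
Compound 2 `COc1cc(CN(C(=O)CSc2nc3ccccc3s2)c2cc(OC)c(OC)c(OC)c2)cc(OC)c1OC`: 45700 nM

Compound 1 holds the lower of the two numbers, making it the stronger inhibitor. Compound 3 `COc1ccc2nc(SCC(=O)N(Cc3ccc(OC)c(O)c3)c3cc(OC)c(OC)c(OC)c3)sc2c1` makes one change to it: methoxy in place of hydrogen on an aromatic carbon. In words, this is methoxy in place of hydrogen on an aromatic carbon. Within the data shown here, the only measured step, a 1300-fold higher number from compound 1 to compound 2 (3.12 log units; beyond the scatter), changes a different part of the molecule, so it shows only that one change can matter greatly here. A moderate rise in this assay seems likeliest because compound 1 already sits at 35 nM. The expected step is a 2.6-fold higher number from compound 1 to compound 3 (0.41 log units; beyond the scatter). Compound 3 is estimated at 90 nM, within a range of 15 nM to 600 nM.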

Compound 3, half-maximal inhibitory concentration: 71 nM
The estimate for compound 3 lay 1.3-fold (0.10 log units) above the measured number; the measured number falls inside the stated range.
By their numbers in this assay, from the lowest: compound 1; then compound 3; then compound 2.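

The change from 1,3-benzothiazol-2-yl to 6-methoxy-1,3-benzothiazol-2-yl gives a 2.0-fold higher number from compound 1 to compound 3 (0.31 log units; beyond the scatter) in this assay and is modest, though beyond the scatter. This position therefore accepts a methoxy group at a far smaller cost than the swap to 3,4,5-trimethoxyphenyl, which gave a 1300-fold higher number from compound 1 to compound 2 (3.12 log units; beyond the scatter) at another part of the molecule. No measurement shown here explains the rise at this position.

On these data alone, whether fluorine, an amine or an ethoxy group at this position would give a lower or higher number stays open. So does whether a methoxy group on another carbon of this ring would behave the same way.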